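Replacing a Methyl with Ethoxy on the Phenyl Ring

A few compounds are considered here, and "the series" means these few. Any claim that something is new, unique, unknown or untested is made for them only; others in the source may bear on it.

Of the compounds shown here, three built on one shared core have been tested in an assay on mitochondria from L6 cells (Rattus norvegicus) for activation, with a stated time of 90 min; on this read-out lower numbers stand for an effect already at smaller amounts and higher numbers for an effect only at larger amounts of compound. Compound 1 `Fc1ccccc1Nc1nc2nonc2nc1NCCC(F)(F)F` carries a 3,3,3-trifluoropropyl on a nitrogen on an aromatic ring; in this assay compound 1 reaches only the limit > 100000 nM (the limit of > 100000 nM in this assay, at which 1 of the 3 values shown sits). Compound 2 `Cc1ccccc1Nc1nc2nonc2nc1Nc1ccccc1F`, with 2-methylphenyl in that place, gives 1100 nM, and compound 3 `Cc1cccc(Nc2nc3nonc3nc2Nc2ccccc2F)c1`, with 3-methylphenyl, gives 1500 nM. Exchanging the chain for an aromatic group brings an at least 90-fold lower number from compound 1 to compound 2 (1.95 log units; beyond the scatter) and an at least 66-fold lower number from compound 1 to compound 3 (1.82 log units; beyond the scatter), whereas moving the methyl from one position to another gives only a 1.4-fold higher number from compound 2 to compound 3 (0.13 log units; within the scatter). Of the two numbers shown, compound 3 stands highest, with compound 2 nearest to it.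

Compound 4 `CCOc1cccc(Nc2nc3nonc3nc2Nc2ccccc2F)c1` has not yet been measured. It differs from compound 3 by ethoxy in place of methyl on an aromatic carbon. Within the data shown here, no measured step swaps a methyl for an ethoxy; the closest guidance is the step between compound 2 and compound 3, which stayed within the scatter. A modest change on the phenyl ring is therefore expected to give a small step, no change at the digits printed from compound 3 to compound 4 (within the scatter), in no clear direction. Compound 4 is estimated at 1500 nM, between 500 nM and 5000 nM.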

Compound 4, half-maximal effective concentration: 2200 nM
Compound 4: middle estimate off by 1.5-fold (0.17 log units), on the low side; the measured number falls inside the stated range.
By their numbers in this assay, from the lowest: compounds 2, 3 and 4 (each within the scatter of the next). At a limit, above all of these: compound 1.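

Ethoxy brings more heavy atoms than methyl and a hydrogen-bond acceptor that methyl lacks, yet at this place on the ring the exchange in this assay gives a 1.5-fold higher number from compound 3 to compound 4 (0.17 log units; within the scatter) and so leaves the read-out within the scatter. A wider change, which alters both the group and its place on the phenyl ring, gives a 2.0-fold higher number from compound 2 to compound 4 (0.30 log units; within the scatter) and also stays within the scatter in this assay. The large step away from the 3,3,3-trifluoropropyl chain also holds for the 3-ethoxyphenyl group, with an at least 45-fold lower number from compound 1 to compound 4 (1.65 log units; beyond the scatter) as the result, but this comparison starts from a limit and not from a number, and compound 1 is the compound at that limit: the limit of > 100000 nM in this assay, at which 1 of the 4 values shown sits.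

On these data alone, it remains open whether an amine, a carboxylic acid or a longer chain on the same ring carbon would also stay within the scatter, or whether such a group would bring a clear step in either direction. The data shown offer no measured property that could account for the small size of the step from methyl to ethoxy.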